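Replacing the propoxycarbonyl group of compound 2

A few compounds are considered here, and "the series" means these few. Any claim that something is new, unique, unknown or untested is made for them only; others in the source may bear on it.

In a functional assay on SK-BR-3 cells (Homo sapiens) for cytotoxicity, read by MTT assay, with a stated time of 72 h (a lower number here means that less compound is needed, a higher number that more compound is needed for the effect), compound 1 `CCc1cccc2c(OC)c(-c3occ(C)c3C(=O)OC)ccc12` gives 1.2 ug/mL. Compound 2 `CCCOC(=O)c1c(C)coc1-c1ccc2c(CC)cccc2c1OC` gives > 10 ug/mL, a limit of the assay and not a number, so it stands at the limit of > 10 ug/mL in this assay, at which 1 of the 2 values shown sits. Compound 3 `CCc1cccc2c(OC)c(-c3occ(C)c3COC)ccc12` differs from compound 2 by one change, methoxymethyl in place of propoxycarbonyl on an aromatic carbon.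

Among the measured compounds shown here, only one measured step bears on this change: an at least 8.3-fold higher number from compound 1 to compound 2 (0.92 log units; beyond the scatter). There, ethyl takes the place of hydrogen on the saturated chain carbon bound to the oxygen next to the carbonyl group. That step links the larger group of compound 2 with the higher number. Methoxymethyl is smaller, but it also has no carbonyl group, and no measured compound tests that loss. A lower number is therefore expected in this assay, with the size of the step uncertain: an at least 2.0-fold lower number from compound 2 to compound 3 (0.30 log units; that floor lies within the scatter). For compound 3 the estimated value is 5 ug/mL, within an expected range of 1.2 ug/mL to 20 ug/mL.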

Compound 3, concentration for half-maximal effect: > 10 ug/mL
Compound 3 gave a limit, no number; the forecaster's own chance of this, stated with the estimate: 30%; at least 2.0-fold (0.30 log units) between middle value and limit.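

In this assay, methoxymethyl in place of methoxycarbonyl on the aromatic carbon gives an at least 8.3-fold higher number from compound 1 to compound 3 (0.92 log units; beyond the scatter). The earlier step tied the higher number to a longer chain on the carbonyl group, whereas this one shows that a group with fewer heavy atoms than propoxycarbonyl and no carbonyl also fails to keep the value of compound 1, so of the three compounds only compound 1 gives a readable number. No step can be read between compound 2 and compound 3, since both stop at the same limit: the limit of > 10 ug/mL in this assay, at which 2 of the 3 values shown sit.

The compounds shown leave open whether compound 1 depends on the carbonyl group itself or on the whole methoxycarbonyl group. From the compounds shown here alone, how ethoxycarbonyl, a carboxylic acid or an amide at this position would read in this assay also stays open.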